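Swapping Trifluoromethoxy for Methyl on a Weak Inhibitor

The source may hold more compounds than are shown below. What is called first, only, known or untested is meant among the compounds shown, and "the series" means these compounds.

Compound 1 `CC(c1ccc(-c2ccccc2)c(F)c1)c1nnc2n1N=C(c1ccc(OC(F)(F)F)cc1)CS2` was tested in a functional assay on Huh-7 cells (Homo sapiens) for inhibition, read by sulforhodamine B assay, with a stated time of 72 h (on this read-out higher numbers stand for weaker inhibition and lower numbers for stronger inhibition), where compound 1 gives 8400 nM. Its two companions sit close by: compound 3 `CC(C)Cc1ccc(C(C)c2nnc3n2N=C(c2ccc(Br)cc2)CS3)cc1` gives 4900 nM in this assay, and compound 2 `COc1ccc2cc(C(C)c3nnc4n3N=C(c3ccc(C(F)(F)F)cc3)CS4)ccc2c1` gives 14800 nM, both within the usual scatter of the number for compound 1. The three share the core yet differ from one another in more than one place, so no single step can be read off among them; their values show only that the series sits together at weak inhibition.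

Compound 4 `Cc1ccc(C2=Nn3c(nnc3C(C)c3ccc(-c4ccccc4)c(F)c3)SC2)cc1` differs from compound 1 in exactly one place: methyl in place of trifluoromethoxy on an aromatic carbon. Going by the values given here, no measured pair isolates this change. Since compounds 1, 2 and 3 each carry a different group on that aryl ring without separating beyond the scatter, the step is expected to be small, a 1.1-fold higher number from compound 1 to compound 4 (0.03 log units; within the scatter), with neither direction favoured. Compound 4 is therefore estimated to give 9000 nM in this assay, expected to fall between 3000 nM and 27000 nM.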

Compound 4, half-maximal inhibitory concentration: 7200 nM
Beside the measured number, compound 4's estimate is 1.3-fold (0.10 log units) above it, within the range that was stated.
By their numbers in this assay, from the lowest: compounds 3, 4, 1 and 2 (each within the scatter of the next, the first and the last beyond it).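

Read on its own for the first time, methyl in place of trifluoromethoxy on an aromatic carbon gives a 1.2-fold lower number from compound 1 to compound 4 (0.07 log units; within the scatter) in this assay. With the rest of the molecule held fixed, this position, para to a large group, therefore does not tell these two groups apart on this read-out, and the weak inhibition seen with compound 1 remains. No available evidence bears on why the two groups read alike.

As far as these compounds go, it remains open whether any group at this position can move the number beyond the scatter, and an amine or a carboxylic acid on the same ring would test that. From the compounds shown here alone, it is also open whether this change would read the same on the other side of the core as it stands in compound 2 or compound 3.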